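Aryl groups on the ring oxygen of the shared core

This account rests on a few compounds, and the source may have more. Where it says the series, first, only, none or still open, it means among the compounds named here.

Measured:
compound 1 `COc1ccc2c(c1)C(n1ccccc1=O)=CC(C)(C)O2` — 6.55
compound 2 `CC1(C)C=C(n2ccccc2=O)c2cc(OCC(=O)c3ccc(F)cc3)ccc2O1` — 4.63

For the measured compounds named here, in a functional assay (aorta) with Rattus norvegicus as the target (on this read-out lower numbers stand for lower potency and higher numbers for higher potency (the scale is a negative logarithm)), compound 2 stands lowest of the two numbers, with compound 1 as its only neighbour. Going by the values given here, the single measured step is a number 1.92 log units lower from compound 1 to compound 2 (beyond the scatter), so placing a bulky aromatic group on that oxygen cost potency heavily.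

Compound 3 `CC1(C)C=C(n2ccccc2=O)c2cc(OC(=O)Nc3ccccc3)ccc2O1` differs from compound 2 by phenylcarbamoyl in place of ((4-fluorophenyl)carbonyl)methyl on an oxygen on an aromatic ring. Among the compounds with values here, only the step from compound 1 to compound 2 bears on it; compound 3 keeps an aromatic group of similar size on the same oxygen, so most of that loss is expected to persist, with a number 0.37 log units higher from compound 2 to compound 3 (beyond the scatter) estimated small. Compound 3 is estimated at 5, range 4.3 to 5.8.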

Compound 3, logarithm of the reciprocal of the active concentration, log(1/C): 5.3
Beside the measured number, compound 3's estimate is 0.30 log units below it, within the range that was stated.
By their numbers in this assay, from the lowest: compound 2; then compound 3; then compound 1.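

In this assay the swap of ((4-fluorophenyl)carbonyl)methyl for phenylcarbamoyl gives a number 0.67 log units higher from compound 2 to compound 3 (beyond the scatter) and shows that the loss at this oxygen depends on the group, not only on the presence of an aromatic ring. Even so, a number 1.25 log units lower from compound 1 to compound 3 (beyond the scatter) remains with phenylcarbamoyl in place of methyl, so both aryl-bearing groups stay behind methyl. No measurement bears on why these groups differ.

Open, on these data alone, is whether the ring or the linking atoms carry the loss. An ethyl or a benzyl group on this oxygen would help separate the two.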